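The source may hold more compounds than are shown below. What is called first, only, known or untested is meant among the compounds shown, and "the series" means these compounds.

In a functional assay on SK-OV-3 cells (Homo sapiens) for inhibition, read by MTT assay (on this read-out lower numbers stand for stronger inhibition and higher numbers for weaker inhibition), compound 1 `COc1ccc(/C=C2\c3cc(OC)c(OC)c(OC)c3CC[C@@H]2O)cc1F` gives 1 nM, compound 2 `COc1ccc(/C=C2\c3cc(OC)c(OC)c(OC)c3CC[C@@H]2O)cc1N` gives 740 nM and compound 3 `COc1ccc(/C=C2\c3cc(OC)c(OC)c(OC)c3CC[C@H]2O)cc1F` gives 720 nM. Compound 3 and compound 2 thus lie within the scatter of each other, and both sit far above compound 1. The step of a 720-fold higher number from compound 1 to compound 3 (2.86 log units; beyond the scatter) traces to the fact that compounds 1 and 3 differ only in the configuration as drawn. Compound 4 `COc1ccc(/C=C2\c3cc(OC)c(OC)c(OC)c3CC[C@H]2O)cc1N` keeps the configuration of compound 3 and carries the change (amino in place of fluoro on an aromatic carbon), from 3-fluoro-4-methoxyphenyl to 3-amino-4-methoxyphenyl. The same exchange on the other configuration gave a 740-fold higher number from compound 1 to compound 2 (2.87 log units; beyond the scatter), starting from the very low value of compound 1. Within the data shown here, no measured step shows this exchange starting from a number as high as that of compound 3, so only part of that size is expected here. The expected step in this assay is a 4.2-fold higher number from compound 3 to compound 4 (0.62 log units; beyond the scatter), upward and large enough to lie beyond the scatter only modestly. For compound 4 the estimated value is 3000 nM, with an expected range of 400 nM to 30000 nM.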

Compound 4, half-maximal inhibitory concentration: 1870 nM
Compound 4: middle estimate off by 1.6-fold (0.21 log units), on the high side, and the stated range covers the measured number.
By their numbers in this assay, from the lowest: compound 1; then compounds 3 and 2 (each within the scatter of the next); then compound 4.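

The exchange of amino for fluoro is small on the configuration of compound 3, a 2.6-fold higher number from compound 3 to compound 4 (0.41 log units; beyond the scatter), so its size depends on the configuration at the saturated ring carbon: the same change on two cores in this assay, a 740-fold higher number (2.87 log units; beyond the scatter) from compound 1 to compound 2 and a 2.6-fold higher number (0.41 log units; beyond the scatter) from compound 3 to compound 4, 280-fold (2.45 log units) apart, beyond the scatter of two such steps. With amino in place, the configuration alone gives a 2.5-fold higher number from compound 2 to compound 4 (0.40 log units; beyond the scatter), far smaller than a 720-fold higher number from compound 1 to compound 3 (2.86 log units; beyond the scatter): the fact that compounds 2 and 4 differ only in the configuration as drawn.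

Open, as far as these compounds go, is whether the very low value of compound 1 is particular to fluoro at this position. A chloro, hydroxyl or methyl group on this aromatic carbon, on the configuration of compound 1, would test this.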